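A few compounds are considered here, and "the series" means these few. Any claim that something is new, unique, unknown or untested is made for them only; others in the source may bear on it.

Working notes on the series.

Compound 1, `CC1=C(C(=O)CC(C)C)C(c2ccoc2)NC(=O)N1`, gives 18% in an assay on membranes from HeLa cells for displacement of a labelled ligand from adenosine receptor A3 (Homo sapiens), read by scintillation counting, with a stated time of 180 min, tested at 1 uM; on this read-out higher numbers stand for more inhibition at the one concentration tested (going by the name of the read-out) and lower numbers for less inhibition. Compound 2, `CC1=C(C(=O)CC(C)C)C(c2cccs2)NC(=O)N1`, gives 18%, and compound 3, `CC1=C(c2ncc(C)o2)C(c2ccoc2)NC(=O)N1`, gives 1%. Compound 1 thus sits level with compound 2 at the digits shown, the two together at the top of the three numbers, while compound 3 lies furthest from it. The step of no change at the digits printed from compound 1 to compound 2 (within the scatter) shows that swapping the group on the saturated ring carbon left the read-out unchanged. The step of a number 17 percentage points lower from compound 1 to compound 3 (beyond the scatter), by contrast, shows that replacing the whole isobutylcarbonyl on the double-bonded ring carbon cost a modest amount.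

Compound 4, `CCC(CC)OC(=O)C1=C(C)NC(=O)NC1c1ccoc1`, keeps the carbonyl and differs from compound 1 only in (pentan-3-yl)oxy in place of isobutyl on a carbonyl carbon. Neither measured step covers this exact change on the carbonyl carbon; the closest, from compound 1 to compound 3, removed the carbonyl altogether. The carbonyl being retained, a step smaller than that one is expected, and a change of a number 6 percentage points lower from compound 1 to compound 4 (within the scatter) is estimated, within the scatter. For compound 4 the expected value is 12%, with a range from 0% to 30%.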

Compound 4, a percentage reported as inhibition, at one concentration (the size of the read-out at that concentration, not a potency): 5%
Compound 4: middle estimate off by 7 percentage points, on the high side; measured number inside the range.
By their numbers in this assay, from the lowest: compounds 3 and 4 (each within the scatter of the next); then compounds 1 and 2 (each within the scatter of the next).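

The step of a number 13 percentage points lower from compound 1 to compound 4 (beyond the scatter) in this assay shows that this position on the double-bonded ring carbon responds to a change even when the carbonyl stays in place. Keeping the carbonyl is therefore not enough to hold the number at the level of compound 1, and the group on the carbonyl carbon also counts. Nothing available on these compounds bears on why the number falls with this change.

Open, on these data alone, is whether a smaller ethoxy or a dimethylamino group on the carbonyl carbon would stay level with compound 1 or fall in the same way. Also open, as far as these compounds go, is whether (pentan-3-yl)oxy gives a similar step with thiophen-2-yl in place of furan-3-yl on the saturated ring carbon.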